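The compounds below may be only part of what the source reports. "The series", "measured", "known", "first", "only" and "open" are said of these compounds alone.

Compound 2 `CNC(=O)N1CCC(CN(C(=O)Nc2ccc(F)c(C(F)(F)F)c2)C2CC[C@]3(c4cccc(C#N)c4)CC3C2)CC1` carries the higher of the two numbers recorded in a functional assay for antagonist activity at melanin-concentrating hormone receptor 1 (Homo sapiens); a higher number here means a weaker inhibitor, a lower number a stronger inhibitor: compound 2 gives 181 nM, while compound 1 `CC(C)N(CCN(C(=O)Nc1cccc([N+](=O)[O-])c1)C1CC[C@]2(c3cccc(C#N)c3)CC2C1)C(C)C` gives 2.7 nM, a gap well beyond the scatter. Compound 3 `CS(=O)(=O)N1CCC(CCN(C(=O)Nc2ccc(F)c(C(F)(F)F)c2)C2CC[C@]3(c4cccc(C#N)c4)CC3C2)CC1` is the next step: (1-(methylsulfonyl)piperidin-4-yl)methyl in place of 1-(methylcarbamoyl)piperidin-4-yl on a saturated chain carbon bound to an amide-type nitrogen. For the measured compounds named here, with no measured pair showing this change, the expectation rests on compound 2 alone; a step toward a lower number is thought plausible but may stay within the scatter, so a 1.8-fold lower number from compound 2 to compound 3 (0.26 log units; within the scatter) is the estimated step. Compound 3 is therefore expected near 100 nM, in a range from 25 nM to 450 nM.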

Compound 3, inhibition constant: 80 nM
Beside the measured number, compound 3's estimate is 1.3-fold (0.10 log units) above it; low and high end bracket the measured number.
By their numbers in this assay, from the lowest: compound 1; then compound 3; then compound 2.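

At this position, on a saturated chain carbon bound to an amide-type nitrogen, replacing 1-(methylcarbamoyl)piperidin-4-yl with (1-(methylsulfonyl)piperidin-4-yl)methyl gives a 2.3-fold lower number from compound 2 to compound 3 (0.35 log units; beyond the scatter) in this assay and so does not cost activity. The change joins two edits, as the methylcarbamoyl group gives way to methylsulfonyl and the methyl link becomes an ethyl link. No measurement here explains the step. The compounds shown do not separate these two edits. They also leave open how a free piperidine amine or a carboxylic acid would read at this position.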